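Replacing fluoro with chloro in compound 2

The source may hold more compounds than are shown below. What is called first, only, known or untested is meant among the compounds shown, and "the series" means these compounds.

Compound 1 `C=C(Br)C(=O)Nc1cccc(/C=C/C(=O)Nc2cccc3ccccc23)c1`: 6500 nM
Compound 2 `C=C(Br)C(=O)Nc1cccc(/C=C/C(=O)Nc2ccc(F)cc2)c1`: 36600 nM
Compound 3 `C=C(Br)C(=O)Nc1cccc(/C=C/C(=O)Nc2cccc(F)c2)c1`: 4600 nM

In a functional assay on HT-29 cells (Homo sapiens) for inhibition, read by MTT assay, with a stated time of 72 h (on this read-out lower numbers stand for stronger inhibition and higher numbers for weaker inhibition), compound 2 has the highest number of the three, clearly weaker than compound 1 and compound 3. Compound 4 `C=C(Br)C(=O)Nc1cccc(/C=C/C(=O)Nc2ccc(Cl)cc2)c1` differs from compound 2 in one place: chloro in place of fluoro on an aromatic carbon. The swap sits para to a large group. Among the compounds with values here, the only measured step that bears on it is an 8.0-fold lower number from compound 2 to compound 3 (0.90 log units; beyond the scatter). Within the data shown here, that step moves the fluoro instead of replacing it, so it shows only that changes on this ring can matter. Among the measured compounds shown here, no measurement yet shows the effect of chloro itself. A small move to a lower number is therefore expected, not clearly beyond the scatter. The expected step is a 1.8-fold lower number from compound 2 to compound 4 (0.26 log units; within the scatter). For compound 4 the estimated value is 20000 nM, with an expected range of 8000 nM to 45000 nM.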

Compound 4, half-maximal inhibitory concentration: 7900 nM
Estimate against measurement, compound 4: 2.5-fold (0.40 log units) above; measured number outside the range, below it.
By their numbers in this assay, from the lowest: compounds 3, 1 and 4 (each within the scatter of the next); then compound 2.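

In this assay, the identity of the group at this position matters, not only where a halogen sits on the ring: chloro in place of fluoro gives a 4.6-fold lower number from compound 2 to compound 4 (0.67 log units; beyond the scatter). Two different single changes to the 4-fluorophenyl compound now end up level, with a 1.7-fold higher number from compound 3 to compound 4 (0.23 log units; within the scatter). No measurement here explains why chloro and fluoro differ.

Going by these compounds, it remains open how a methyl, methoxy or amine group would behave at this position. It is also unknown whether a 3-chlorophenyl group would match the 3-fluorophenyl group.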